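A few compounds are considered here, and "the series" means these few. Any claim that something is new, unique, unknown or untested is made for them only; others in the source may bear on it.

Measured compounds so far:

- compound 1 `Cc1ccc2nc(Nc3nc(Nc4ccc(S(N)(=O)=O)cc4)ncc3C)sc2c1`. In a functional assay on MCF7 cells (Homo sapiens) for antiproliferative activity, read by MTT assay, with a stated time of 48 h (on this read-out higher numbers stand for weaker inhibition and lower numbers for stronger inhibition), compound 1 gives only a limit, > 50000 nM.
- compound 2 `CS(=O)(=O)c1ccc(Nc2nccc(Nc3nc4ccc(F)cc4s3)n2)cc1`. In this assay compound 2 gives only a limit, > 60000 nM.
- compound 3 `Cc1cnc(Nc2ccc(S(N)(=O)=O)cc2)nc1Nc1nc2ccccc2s1`. In this assay compound 3 gives only a limit, > 50000 nM.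

None of the three is a number: two of the values sit at the limit of > 50000 nM in this assay, at which 2 of the 3 values shown sit, and one at the limit of > 60000 nM in this assay, at which 1 of the 3 values shown sits. Compound 1 is obtained from compound 3 by methyl in place of hydrogen on an aromatic carbon; the resulting step, a step that the two limits leave unreadable from compound 3 to compound 1, cannot be read because the limit of > 50000 nM in this assay, at which 2 of the 3 values shown sit, holds both of its ends. Compound 2 and compound 3 differ in more than one place, and the difference between the two cores is not broken down here.

Compound 4 `Cc1cnc(Nc2ccc(S(C)(=O)=O)cc2)nc1Nc1nc2ccc(F)cc2s1` has not been measured. It comes from compound 2 by methyl in place of hydrogen on an aromatic carbon. The place is not the same as in compound 1: there the methyl enters on a six-membered aromatic ring of carbon only, part of a fused or bridged system of two rings, meta to a fused ring and para to a fused ring; here it enters on a six-membered aromatic ring with 2 nitrogen, ortho to a large group, two atoms from the ring nitrogen and para to a large group. It is therefore the same kind of change, not the same change.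

In this assay the step from compound 2 to compound 4 is expected to be a number no higher from compound 2 to compound 4 (the limit leaves the size open), and this expectation rests only on the unreadable earlier step that the two limits leave unreadable from compound 3 to compound 1 and on (the limit of > 60000 nM in this assay, at which 1 of the 3 values shown sits). Compound 4 is thus expected to give about 60000 nM, most likely again as a limit rather than a number, with a range from 15000 nM to 250000 nM.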

Compound 4, half-maximal inhibitory concentration: 3260 nM
Beside the measured number, compound 4's estimate is 18-fold (1.26 log units) above it; the whole stated range lies above it.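

In this assay, methyl in place of hydrogen on an aromatic carbon of the six-membered aromatic ring with 2 nitrogen gives an at least 18-fold lower number from compound 2 to compound 4 (1.26 log units; beyond the scatter), the only step shown so far whose direction can be read. Compound 2 gives only a limit, > 60000 nM. This single step does not show that the change carries from one core to another, since the only other methyl step enters on a six-membered aromatic ring of carbon only and cannot be read, with both of its ends held at one limit: the limit of > 50000 nM in this assay, at which 2 of the 4 values shown sit.

Whether a hydrogen-to-methyl change at this same place gives a step of similar size on the core of compound 3 remains open, since the compounds shown offer one readable pair and so no second case to set against it. Also open is what other groups on this aromatic carbon would do, for example an ethyl group, an amine or a carboxylic acid, since the compounds shown carry only hydrogen or methyl there.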